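The compounds below may be only part of what the source reports. "The series", "measured", "known", "first", "only" and "open" are said of these compounds alone.

Of the compounds shown here, three of a shared core have been measured in a functional assay on MDA-MB-231 cells (Homo sapiens) for inhibition, read by MTT assay, with a stated time of 72 h; on this read-out lower numbers stand for stronger inhibition and higher numbers for weaker inhibition. Among the measured compounds shown here, compound 1 `O=C(CSc1nc(Nc2ccccc2)c2ccccc2n1)Nc1cccc(Br)c1` gives 17500 nM, and compound 2 `O=C(CSc1nc(Nc2ccccc2)c2ccccc2n1)Nc1cccc([N+](=O)[O-])c1` gives 33000 nM; the one step between them, nitro in place of bromo on an aromatic carbon, is a 1.9-fold higher number from compound 1 to compound 2 (0.28 log units; within the scatter). Compound 3 `C=CC(=O)Nc1cccc(NC(=O)CSc2nc(Nc3cccc(F)c3)c3ccccc3n2)c1` gives 8160 nM, the lowest of the three numbers, beyond the scatter from both compound 1 and compound 2.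

The next compound, compound 4 `C=CC(=O)Nc1cccc(NC(=O)CSc2nc(Nc3ccc(CC)cc3)c3ccccc3n2)c1`, differs from compound 3 in one place: 4-ethylphenyl in place of 3-fluorophenyl on a nitrogen on an aromatic ring. For the measured compounds named here, no measured step touches this position: the only step on record, from compound 1 to compound 2, sits on the other aryl amide and says nothing about the group on the aromatic nitrogen. With no comparison of the same kind to lean on, the expected step in this assay is none beyond the scatter, in either direction, and the estimate is widened accordingly. Compound 4 is therefore expected at 9000 nM, in a range from 3000 nM to 27000 nM, which corresponds to an expected step of a 1.1-fold higher number from compound 3 to compound 4 (0.04 log units; within the scatter).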

Compound 4, half-maximal inhibitory concentration: 14400 nM
The estimate for compound 4 lay 1.6-fold (0.20 log units) below the measured number; low and high end bracket the measured number.
By their numbers in this assay, from the lowest: compounds 3, 4, 1 and 2 (each within the scatter of the next, the first and the last beyond it).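

In this assay, the group on the aromatic nitrogen now has its first measured step, a 1.8-fold higher number from compound 3 to compound 4 (0.25 log units; within the scatter). This position therefore accepts 4-ethylphenyl in place of 3-fluorophenyl with no change beyond the scatter, although both the substituent and the number in its name differ, so this single step cannot separate the two. No evidence is available that bears on this result.

As far as these compounds go, whether 3-ethylphenyl or 4-fluorophenyl would read the same as these two groups remains open, and only such compounds could separate the substituent from its place on the ring. Also open, from the compounds shown here alone, is whether an amine, a carboxylic acid or a longer chain than ethyl on this ring would give a step beyond the scatter.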